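A few compounds are considered here, and "the series" means these few. Any claim that something is new, unique, unknown or untested is made for them only; others in the source may bear on it.

Measured so far:
compound 1 `Cc1ccccc1NC(=O)Nc1cccc(CNc2ncnc3ccccc23)c1` — 40200 nM
compound 2 `Cc1cccc(NC(=O)Nc2cccc(CNc3ncnc4ccccc34)c2)c1` — 30200 nM
compound 3 `COc1cc2ncnc(NCc3cccc(NC(=O)Nc4ccccc4C)c3)c2cc1OC` — 21400 nM

All three were read in a functional assay on A549 cells (Homo sapiens) for antiproliferative activity, read by MTT assay; a lower number here means a stronger inhibitor, a higher number a weaker inhibitor. Compound 1 and compound 2 share a core and differ by 3-methylphenyl in place of 2-methylphenyl on an amide-type nitrogen; the step of a 1.3-fold lower number from compound 1 to compound 2 (0.12 log units; within the scatter) is within the scatter. Compound 3 carries a different core; the difference between the two cores is not broken down here, and the values of compound 1 and compound 3 lie within the scatter of each other.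

Compound 4 `COc1cc2ncnc(NCc3cccc(NC(=O)Nc4cccc(C)c4)c3)c2cc1OC` is not yet measured. It differs from compound 3 by 3-methylphenyl in place of 2-methylphenyl on an amide-type nitrogen, the same change as from compound 1 to compound 2, at the same kind of place. Beside a 1.3-fold lower number from compound 1 to compound 2 (0.12 log units; within the scatter), the step from compound 3 to compound 4 is expected to be a 1.3-fold lower number from compound 3 to compound 4 (0.10 log units; within the scatter), resting on compound 1 and compound 2 alone. Compound 4 is therefore estimated at 17000 nM, between 8000 nM and 36000 nM.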

Compound 4, half-maximal inhibitory concentration: 27100 nM
Estimate against measurement, compound 4: 1.6-fold (0.20 log units) below; measured number inside the range.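

In this assay, 3-methylphenyl in place of 2-methylphenyl on an amide-type nitrogen gives a 1.3-fold higher number from compound 3 to compound 4 (0.10 log units; within the scatter). Set beside the same change on the core of compound 1, the step shows no difference between the two cores: the same change on two cores in this assay, a 1.3-fold lower number (0.12 log units; within the scatter) from compound 1 to compound 2 and a 1.3-fold higher number (0.10 log units; within the scatter) from compound 3 to compound 4, 1.7-fold (0.23 log units) apart, within the scatter of two such steps. Within the data shown here, this shows only that the change stays within the scatter on both cores; neither step stands clear of it, so no size or direction can be said to carry from one core to the other.

The compounds shown leave open whether a group other than methyl on that phenyl ring, such as trifluoromethyl or a carboxylic acid, would give a step beyond the scatter. As far as these compounds go, whether such a step would then carry between the two cores also remains open.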